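Thienyl dihydropyrimidinones: ester chain shortening at the carbonyl

The source may report more compounds than this note shows. Statements on the series, on what has been measured and on what is new or still open speak of the compounds shown alone.

Measured so far:
compound 1 `CCN(CC)C(=O)C1=C(C)NC(=O)NC1c1ccsc1`, 11%
compound 2 `CCC(CC)OC(=O)C1=C(C)NC(=O)NC1c1ccsc1`, 22%

In an assay on membranes from CHO cells for displacement of a labelled ligand from adenosine receptor A1 (Homo sapiens), read by scintillation counting, with a stated time of 60 min, tested at 1 uM (on this read-out higher numbers stand for more inhibition at the one concentration tested (going by the name of the read-out) and lower numbers for less inhibition), compound 2 gives the higher of the two numbers; compound 1 lies a step below, a number 11 percentage points higher from compound 1 to compound 2 (beyond the scatter). Compound 3 `CCC(C)OC(=O)C1=C(C)NC(=O)NC1c1ccsc1` differs from compound 2 by hydrogen in place of methyl on a saturated chain carbon, two bonds along the chain from an oxygen next to a carbonyl group. For the measured compounds named here, no measured step bears on this change: the one step on record swaps the group on the carbonyl carbon, not a methyl on the chain. With nothing to go on, a step within the scatter is expected, a number 4 percentage points lower from compound 2 to compound 3 (within the scatter). Compound 3 is estimated at 18%, between 5% and 32%.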

Compound 3, a percentage reported as inhibition, at one concentration (the size of the read-out at that concentration, not a potency): 5%
Estimate against measurement, compound 3: 13 percentage points above, and the stated range covers the measured number.
By their numbers in this assay, from the lowest: compounds 3 and 1 (each within the scatter of the next); then compound 2.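

In this assay the methyl on this saturated chain carbon counts: its loss gives a number 17 percentage points lower from compound 2 to compound 3 (beyond the scatter) and so pentan-3-yl and sec-butyl are not interchangeable on this ester oxygen. Sec-butoxy in place of diethylamino gives a number 6 percentage points lower from compound 1 to compound 3 (within the scatter) so the gain held by (pentan-3-yl)oxy over diethylamino does not carry over to the shorter ester. On these data alone, whether a longer chain, a cyclopentyl ester or a plain ethyl ester would continue or break this trend remains open. Nothing on hand accounts for the size of this step.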